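The compounds below may be only part of what the source reports. "The series", "measured", "known", "first", "only" and "open" are said of these compounds alone.

Measured so far in a functional assay on cells (Platelet, Homo sapiens) for inhibition (a higher number here means a weaker inhibitor, a lower number a stronger inhibitor), are these:
- compound 1 `CCOC(=O)c1ccc(-c2nn(CC)c3ccccc23)cc1` gives 360 nM as a number
- compound 2 `NC(=O)c1ccc(-c2nn(Cc3ccccc3)c3ccccc23)cc1` gives > 10000 nM as a limit
- compound 3 `CNC(=O)c1ccc(-c2nn(Cc3ccccc3)c3ccccc23)cc1` gives > 10000 nM as a limit

Compound 3 stands at the limit of > 10000 nM in this assay, at which 2 of the 3 values shown sit, and so offers no number to step from. Compound 4 `OCc1ccc(-c2nn(Cc3ccccc3)c3ccccc23)cc1` carries hydroxymethyl in place of methylcarbamoyl on an aromatic carbon, para to a large group (hydroxymethyl in place of methylcarbamoyl on an aromatic carbon). Among the measured compounds shown here, the one measured step is a step that the two limits leave unreadable from compound 2 to compound 3 and gives no size to carry over. For the measured compounds named here, compound 1 gives 360 nM in this assay and shows only that an exact number can be obtained there. A modest at least 2.5-fold lower number from compound 3 to compound 4 (0.39 log units; beyond the scatter) towards stronger inhibition is expected, though a result again at the limit is about as likely. For compound 4 the estimate is 4000 nM with 700 nM to 10000 nM as the expected range.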

Compound 4, half-maximal inhibitory concentration: > 10000 nM
Compound 4 gave a limit, no number (the forecaster's own chance of this, stated with the estimate: 45%); middle value at least 2.5-fold (0.39 log units) from the limit.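

In this assay no step among compound 2, compound 3 and compound 4 can be read, since each gives only a limit and not a number: the limit of > 10000 nM in this assay, at which 3 of the 4 values shown sit.

As far as these compounds go, how these three compounds rank against one another remains open.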